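The compounds below may be only part of what the source reports. "The series", "measured", "known", "first", "only" and "open" are said of these compounds alone.

The measured compounds and their values:

Compound 1, `CN(C)C(=O)c1cc2cnc(Nc3ccc(NC(=O)C4(C(=O)Nc5ccccc5)CC4)cc3)nc2n1C1CCCC1`: 106%
Compound 2, `CN(C)C(=O)c1cc2cnc(Nc3ccc(NC(=O)C4(C(=O)Nc5ccccc5F)CC4)cc3)nc2n1C1CCCC1`: 103%

Both values come from a functional assay on SiHa cells (Homo sapiens) for inhibition, read by CCK-8 assay, with a stated time of 72 h, tested at 10 uM; a lower number here means less inhibition of growth, a higher number more inhibition of growth at the concentration tested. In this assay compound 1 gives 106% and compound 2 gives 103%. For the measured compounds named here, the single measured step, a number 3 percentage points lower from compound 1 to compound 2 (within the scatter), shows that the two numbers cannot be told apart, so compound 2 stands level with compound 1, both near complete inhibition of growth at the concentration tested.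

Compound 3, `CN(C)C(=O)c1cc2cnc(Nc3ccc(NC(=O)C4(C(=O)Nc5cccc(O)c5)CC4)cc3)nc2n1C1CCCC1`, is not yet measured. It differs from compound 2 in one place: 3-hydroxyphenyl in place of 2-fluorophenyl on an amide-type nitrogen. Going by the values given here, the only measured step concerns a fluoro in place of hydrogen on an aromatic carbon and was within the scatter, and no measured pair speaks to a 3-hydroxyphenyl on the amide-type nitrogen. Among the compounds with values here, the step from compound 2 to compound 3 therefore has no close precedent, and with both measured values already near the top of the read-out, a change beyond the scatter is not expected in either direction. The expected step is a number 3 percentage points lower from compound 2 to compound 3 (within the scatter). For compound 3 the estimate is 100%, with a range from 85% to 110%.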

Compound 3, percent growth inhibition at one concentration: 75.7%
Estimate against measurement, compound 3: 24.3 percentage points above, and the stated range ends above it.
By their numbers in this assay, from the lowest: compound 3; then compounds 2 and 1 (each within the scatter of the next).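

The group on the amide-type nitrogen turns out to matter in this assay: fluoro in place of hydrogen had left the number within the scatter, but 3-hydroxyphenyl in place of 2-fluorophenyl gives a number 27.3 percentage points lower from compound 2 to compound 3 (beyond the scatter), and a hydroxy group added to the aromatic ring that carries no fluoro gives a number 30.3 percentage points lower from compound 1 to compound 3 (beyond the scatter). For the compounds shown here, the plateau near complete inhibition of growth seen so far therefore does not hold for every substituent on this aromatic ring, and the one group that breaks it is also the one that brings a hydrogen-bond donor and a hydrogen-bond acceptor, a count that is zero for 2-fluorophenyl. Nothing available here accounts for this drop in growth inhibition.

The compounds shown leave open whether the drop follows the hydroxy group itself or the place it occupies on the ring, since the step from compound 2 to compound 3 changes both the substituent and its place. Also open, from the compounds shown here alone, is how a methoxy group, an amine or a carboxylic acid on this ring would read at the concentration tested.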